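Chloro in place of nitro: expectation for compound 3

The compounds below may be only part of what the source reports. "The series", "measured", "known", "first", "only" and "open" are said of these compounds alone.

Within the data shown here, in a functional assay on FM3A cells (Mus musculus) for antiproliferative activity (a higher number here means a weaker inhibitor, a lower number a stronger inhibitor), compound 2 (`COc1cc(C(=O)c2sc(-c3ccc([N+](=O)[O-])cc3)cc2N)cc(OC)c1OC`) gives 64 nM, the only actual number so far. Compound 1 (`COc1cc(C(=O)c2sc(-c3ccc(-c4ccccc4)cc3)cc2N)cc(OC)c1OC`) reads > 10000 nM, which is a limit of the assay and not a number. Among the measured compounds shown here, the one measured step, an at least 150-fold lower number from compound 1 to compound 2 (2.19 log units; beyond the scatter), is large and beyond the scatter, with nitro in place of phenyl on an aromatic carbon. It shows that a change at this place can matter greatly. Compound 3 (`COc1cc(C(=O)c2sc(-c3ccc(Cl)cc3)cc2N)cc(OC)c1OC`) changes the same place: chloro in place of nitro on an aromatic carbon. Unlike the measured step, this one involves no ring, so a much smaller step is expected in this assay. A modest rise is the likeliest direction, although one step settles direction poorly. The expected change is a 1.7-fold higher number from compound 2 to compound 3 (0.24 log units; within the scatter). For compound 3 the estimated value is 110 nM, with an expected range of 30 nM to 500 nM.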

Compound 3, half-maximal inhibitory concentration: 90 nM
For compound 3 the middle estimate is 1.2-fold (0.09 log units) above the measured one; the range from low to high includes it.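

In this assay, chloro in place of nitro gives a 1.4-fold higher number from compound 2 to compound 3 (0.15 log units; within the scatter), so two groups without a ring, of different heavy-atom count and atoms, read alike at this place, para to a large group. Chloro in place of phenyl gives an at least 110-fold lower number from compound 1 to compound 3 (2.04 log units; beyond the scatter), so the large step from compound 1 is no longer tied to nitro alone and now appears with two different groups. Compound 1 stands at a limit and not at a number, so both steps from it give only a bound: the limit of > 10000 nM in this assay, at which 1 of the 3 values shown sits.

Going by these compounds, whether an amine, a methoxy or a carboxylic acid at this place would read like compound 2 and compound 3 remains open. Also open, on these data alone, is whether a second ring of any kind, such as a pyridine or a cyclopropyl, would read like compound 1.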